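Chain extension on the fluorinated analogue: expected loss

The source may report more compounds than this note shows. Statements on the series, on what has been measured and on what is new or still open speak of the compounds shown alone.

Compound 3 `CN(C)C(=O)c1cc2cnc(Nc3ccc(C(=O)NCCCN=C=S)cc3F)nc2n1C1CCCC1` gives 78.5% in a functional assay on NCI-H1299 cells (Homo sapiens) for inhibition, read by CCK-8 assay, with a stated time of 72 h, tested at 10 uM; on this read-out lower numbers stand for a weaker effect and higher numbers for a stronger effect at the one concentration tested. Among the three measured compounds it holds the second highest number; compound 2 `CN(C)C(=O)c1cc2cnc(Nc3ccc(C(=O)NCCCCCN=C=S)cc3)nc2n1C1CCCC1` gives 76.5%, a value within the scatter of compound 3, while compound 1 `CN(C)C(=O)c1cc2cnc(Nc3ccc(C(=O)NCCCN=C=S)cc3)nc2n1C1CCCC1` gives 91.2%, separated from compound 3 by a number 12.7 percentage points lower from compound 1 to compound 3 (beyond the scatter), a change of fluoro in place of hydrogen on an aromatic carbon.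

Compound 4 `CN(C)C(=O)c1cc2cnc(Nc3ccc(C(=O)NCCCCCN=C=S)cc3F)nc2n1C1CCCC1` has not yet been measured in this assay. It differs from compound 3 by a group of 5 heavy atoms (3 carbon, 1 nitrogen, 1 sulfur; no ring) in place of a group of 3 heavy atoms (1 carbon, 1 nitrogen, 1 sulfur; no ring), on a saturated chain carbon, three bonds along the chain from an amide-type nitrogen. The same change has already been seen once, on the unfluorinated pair, where it gave a number 14.7 percentage points lower from compound 1 to compound 2 (beyond the scatter). Among the compounds with values here, that single step is the only guide available, and it points downward by a modest amount beyond the scatter.

Compound 4 is therefore expected to show a lower number than compound 3 by about a number 14.5 percentage points lower from compound 3 to compound 4 (beyond the scatter). The estimate for compound 4 in this assay is 64%, with a plausible range from 50% to 76%.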

Compound 4, a percentage reported as inhibition, at one concentration (the size of the read-out at that concentration, not a potency): 86.7%
For compound 4 the middle estimate is 22.7 percentage points below the measured one, outside the stated range (above it).
By their numbers in this assay, from the lowest: compounds 2, 3, 4 and 1 (each within the scatter of the next, the first and the last beyond it).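

In this assay, the chain extension does not carry over from one core to the other: the step of a number 8.2 percentage points higher from compound 3 to compound 4 (within the scatter) shows no repeat of the loss seen on the unfluorinated pair, and the two readings of the same change part clearly: the same change on two cores in this assay, a number 14.7 percentage points lower (beyond the scatter) from compound 1 to compound 2 and a number 8.2 percentage points higher (within the scatter) from compound 3 to compound 4, 22.9 percentage points apart, beyond the scatter of two such steps. Fluoro in place of hydrogen on an aromatic carbon also changes with the chain, with a number 10.2 percentage points higher from compound 2 to compound 4 (beyond the scatter) standing against the earlier loss on the shorter chain: the same change on two cores in this assay, a number 12.7 percentage points lower (beyond the scatter) from compound 1 to compound 3 and a number 10.2 percentage points higher (beyond the scatter) from compound 2 to compound 4, 22.9 percentage points apart, beyond the scatter of two such steps. Neither change therefore has a single direction in this set, and each must be read together with the other, which the earlier single steps could not show.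

Going by these compounds, how a still longer chain, or chloro in place of fluoro, would behave on either core remains open. On these data alone, these readings come from one concentration, so the relative potency of the compounds also remains open.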